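A Side-Chain Exchange on Compound 2

This account rests on a few compounds, and the source may have more. Where it says the series, first, only, none or still open, it means among the compounds named here.

Measured in an ADME assay on S9 fraction from liver (Mus musculus, strain CD-1) for metabolic stability, read by LC-MS, using NADPH, with stated times of 5 min and 60 min, tested at 5 uM; on this read-out higher numbers stand for a more stable compound and lower numbers for a less stable compound:
- compound 1 `COc1ccc(COc2ccc(C3CN(C(=O)c4cc(OCCO)ccn4)C3)cc2OC)cc1`: 48%
- compound 2 `COc1cc(C2CN(C(=O)c3cc(OC[C@@H](O)CO)ccn3)C2)ccc1OCc1ccc(C2CC2)cc1`: 68%
- compound 3 `CCc1ccc(COc2ccc(C3CN(C(=O)c4cc(COCC(CO)(CO)CO)ccn4)C3)cc2OC)cc1`: 71%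

Compound 2 gives 68%, which lies within the scatter of compound 3 and beyond the scatter above compound 1. Compound 4 `COc1cc(C2CN(C(=O)c3cc(COCC(CO)CO)ccn3)C2)ccc1OCc1ccc(C2CC2)cc1` has not yet been measured. It differs from compound 2 at one place: (3-hydroxy-2-(hydroxymethyl)propoxy)methyl in place of 2,3-dihydroxypropoxy on an aromatic carbon. There, (3-hydroxy-2-(hydroxymethyl)propoxy)methyl stands in place of 2,3-dihydroxypropoxy on an aromatic carbon.

Among the measured compounds shown here, no two measured compounds differ in only one place, so no measured step can guide the expectation. In this assay, no step beyond the scatter is expected, in either direction. This expectation rests on limited evidence. Compound 3, which carries a chain of a similar kind, gives 71%. The expected step is a number 1 percentage points higher from compound 2 to compound 4 (within the scatter). For compound 4 the estimated value is 69%, with an expected range of 54% to 82%.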

Compound 4, percent of the compound remaining: 66%
Compound 4: the middle estimate sits 3 percentage points above what was measured; the measured number falls inside the stated range.
By their numbers in this assay, from the lowest: compound 1; then compounds 4, 2 and 3 (each within the scatter of the next).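

In this assay the exchange of 2,3-dihydroxypropoxy for (3-hydroxy-2-(hydroxymethyl)propoxy)methyl provides the only one-place comparison shown, and the result is a number 2 percentage points lower from compound 2 to compound 4 (within the scatter) for this change. On the aromatic carbon opposite the ring nitrogen, the chain can therefore go from 6 to 8 heavy atoms and lose its defined stereocentre, with its hydrogen-bond donor and acceptor counts unchanged, without a step beyond the scatter. Nothing available explains why the number holds at this position.

The compounds shown leave open whether this tolerance in this assay extends to a chain of another kind at this position, such as one ending in an amine or a carboxylic acid. They also leave open whether a longer chain would give a step beyond the scatter.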